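Chloropropylurea sulfonyl series: ester versus anilide cores

This account rests on a few compounds, and the source may have more. Where it says the series, first, only, none or still open, it means among the compounds named here.

Measured compounds:
compound 1 `CCc1ccccc1OS(=O)(=O)c1cccc(NC(=O)NCCCCl)c1` gives 25000 nM
compound 2 `CCCc1ccccc1OS(=O)(=O)c1cccc(NC(=O)NCCCCl)c1` gives 14000 nM
compound 3 `CCc1ccccc1NS(=O)(=O)c1cccc(NC(=O)NCCCCl)c1` gives 43000 nM

All three values come from a functional assay on MCF7 cells (Homo sapiens) for cytotoxicity, read by sulforhodamine B assay, with a stated time of 48 h; on this read-out higher numbers stand for weaker inhibition and lower numbers for stronger inhibition. Compound 1 and compound 2 share one core; compound 3 carries the other, and the difference between the two cores is not broken down here. Within the first core, the change methyl in place of hydrogen on a saturated chain carbon, two bonds along the chain from an aromatic carbon gave a 1.8-fold lower number from compound 1 to compound 2 (0.25 log units; within the scatter), a step that stays within the scatter, so no direction can be read from it with confidence.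

Compound 3 stands at the highest number of the three. Against compound 1 the gap is within the scatter, against compound 2 it lies beyond it, so compound 3 is separated from compound 2 but not from compound 1 on this read-out.

Compound 4 `CCCc1ccccc1NS(=O)(=O)c1cccc(NC(=O)NCCCCl)c1` has not yet been measured. Among the compounds with values here, it differs from compound 3 by methyl in place of hydrogen on a saturated chain carbon, two bonds along the chain from an aromatic carbon, which is the same change as the one from compound 1 to compound 2, made on the other core. The expectation for compound 4 rests on a single precedent, the step of a 1.8-fold lower number from compound 1 to compound 2 (0.25 log units; within the scatter), and on the value of compound 3, 43000 nM. On that basis compound 4 is estimated to reach 25000 nM, which means an expected step of a 1.7-fold lower number from compound 3 to compound 4 (0.24 log units; within the scatter) in this assay. Within the data shown here, the expected range for compound 4 is set wide, from 10000 nM to 60000 nM, because the one precedent a 1.8-fold lower number from compound 1 to compound 2 (0.25 log units; within the scatter) is itself within the scatter and the cores differ.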

Compound 4, half-maximal inhibitory concentration: 18000 nM
Compound 4: middle estimate off by 1.4-fold (0.14 log units), on the high side; low and high end bracket the measured number.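

In this assay, the change from 2-ethylphenyl to 2-propylphenyl on the second core gave a 2.4-fold lower number from compound 3 to compound 4 (0.38 log units; beyond the scatter), and the two steps for this change do not differ measurably between the cores: the same change on two cores in this assay, a 1.8-fold lower number (0.25 log units; within the scatter) from compound 1 to compound 2 and a 2.4-fold lower number (0.38 log units; beyond the scatter) from compound 3 to compound 4, 1.3-fold (0.13 log units) apart, within the scatter of two such steps

Within this series, the change therefore carries from one core to the other without a detectable difference in size, and only on the second core does the step itself lie beyond the scatter. This does not establish a general rule for transfer between cores, since the comparison rests on one matched pair per core, one of them within the scatter, and on a single cell assay, and it gives no explanation for the lower number.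

The compounds shown leave open whether the trend continues past propyl, for example with a butyl chain, or how a branched isopropyl group or a methoxy group would behave at the same place on either core. They also leave open how either core would respond to changes elsewhere, such as an amine or a hydroxyl group in place of the chlorine on the chloropropyl chain.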